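Cytotoxicity of a shared core with varied aryl substituents

The compounds below may be only part of what the source reports. "The series", "measured", "known", "first", "only" and "open" are said of these compounds alone.

Compound 1, `CCc1ccc(-c2nc3c(c(C)nn3-c3ccccc3)c(-c3ccccc3[N+](=O)[O-])c2C#N)cc1`, in an ADME assay on BJ cells (Homo sapiens) for cytotoxicity, with a stated time of 72 h; a higher number here means that more compound is needed for the effect, a lower number that less compound is needed: > 20000 nM, a limit of the assay.
Compound 2, `CCc1ccc(-c2nc3c(c(C)nn3-c3ccccc3)c(-c3ccccc3I)c2C#N)cc1`, in this assay: > 20000 nM, a limit of the assay.
Compound 3, `CCc1ccc(-c2nc3c(c(C)nn3-c3ccccc3)c(-c3cccc(O)c3)c2C#N)cc1`, in this assay: > 20000 nM, a limit of the assay.

All three measured compounds share one core and differ only in the aryl group attached to it. None of them gives a number in this assay; each result is a limit, and the evidence amounts to the limit of > 20000 nM in this assay, at which 3 of the 3 values shown sit. Compound 2 therefore stands only at a limit, with the other two values shown also being limits. The three steps among them are unreadable for that reason: a step that the two limits leave unreadable from compound 1 to compound 2, a step that the two limits leave unreadable from compound 1 to compound 3 and a step that the two limits leave unreadable from compound 2 to compound 3.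

Compound 4, `CCc1ccc(-c2nc3c(c(C)nn3-c3ccccc3)c(-c3ccccc3C(=O)OC)c2C#N)cc1`, is not yet measured. It differs from compound 2 by methoxycarbonyl in place of iodo on an aromatic carbon. Going by the values given here, no measured step gives a readable size, so nothing in the data points toward a step beyond the scatter in either direction; the only expectation is that compound 4, like every measured compound, is most likely to reach the limit again. The step from compound 2 to compound 4 is estimated as a step that the limit leaves unreadable from compound 2 to compound 4. Compound 4 is expected to give about 30000 nM, within a range from 15000 nM to 100000 nM.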

Compound 4, half-maximal effective concentration: > 20000 nM
Compound 4: only a limit was reported; the forecaster's own chance of this, stated with the estimate: 85%; the middle value lies beyond the limit too.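

Compound 4, like compound 1, compound 2 and compound 3, gives only a limit of the assay, and no step among these four compounds can be read. The compounds shown leave open whether any aryl group on the shared core brings this assay to a readable value.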